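Replacing the 2,3-dimethoxyphenyl group of compound 3

The source may report more compounds than this note shows. Statements on the series, on what has been measured and on what is new or still open speak of the compounds shown alone.

In a functional assay on HeLa cells (Homo sapiens) for inhibition, read by MTT assay, with a stated time of 48 h (a higher number here means a weaker inhibitor, a lower number a stronger inhibitor), compound 1 (`Brc1ccc2[nH]cc(C(c3ccccc3)c3c[nH]c4ccc(Br)cc34)c2c1`) gives 900 nM, compound 2 (`COc1ccc(C(c2c[nH]c3ccc(Br)cc23)c2c[nH]c3ccc(Br)cc23)cc1`) gives 5500 nM, and compound 3 (`COc1cccc(C(c2c[nH]c3ccc(Br)cc23)c2c[nH]c3ccc(Br)cc23)c1OC`) gives 64500 nM, the highest number of the three and so the weakest inhibitor here. Compound 4 (`Brc1ccc(C(c2c[nH]c3ccc(Br)cc23)c2c[nH]c3ccc(Br)cc23)cc1`) carries 4-bromophenyl in place of 2,3-dimethoxyphenyl on a saturated chain carbon bound to two aromatic carbons. Two large measured steps bear on this change: a 12-fold higher number from compound 2 to compound 3 (1.07 log units; beyond the scatter), and a 72-fold higher number from compound 1 to compound 3 (1.86 log units; beyond the scatter). A third step, a 6.1-fold higher number from compound 1 to compound 2 (0.79 log units; beyond the scatter), is only modest. Going by the values given here, no 4-bromophenyl compound has been measured yet, but a large fall in this assay is expected, an estimated 16-fold lower number from compound 3 to compound 4 (1.21 log units; beyond the scatter). For compound 4 the expected value is 4000 nM, with an estimated range from 1000 nM to 16000 nM.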

Compound 4, half-maximal inhibitory concentration: 1500 nM
Compound 4: the middle estimate sits 2.7-fold (0.43 log units) above what was measured; measured number inside the range.
By their numbers in this assay, from the lowest: compounds 1 and 4 (each within the scatter of the next); then compound 2; then compound 3.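

In this assay, 4-bromophenyl at this position gives a 43-fold lower number from compound 3 to compound 4 (1.63 log units; beyond the scatter), which shows that the high number of compound 3 does not extend to every substituted phenyl on the saturated chain carbon. Bromo in place of methoxy gives a 3.7-fold lower number from compound 2 to compound 4 (0.56 log units; beyond the scatter), whereas bromo in place of hydrogen gives a 1.7-fold higher number from compound 1 to compound 4 (0.22 log units; within the scatter), so compound 1 and compound 4 cannot be told apart. Thus, a substituent on this ring need not raise the number, although compound 2 and compound 3 both stand higher.

Nothing measured here accounts for these differences. From the compounds shown here alone, whether an amine or a carboxylic acid on this ring would match bromo remains open.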